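The source may hold more compounds than are shown below. What is called first, only, known or untested is meant among the compounds shown, and "the series" means these compounds.

Measured in an ADME assay on HepG2 cells (Homo sapiens) for cytotoxicity, read by MTT assay, with a stated time of 48 h; on this read-out lower numbers stand for stronger inhibition and higher numbers for weaker inhibition:
- Compound 1 `O=S(=O)(c1ccc(-c2ccc3ncnc(Nc4ccc(OCc5cccc(F)c5)c(Cl)c4)c3c2)cc1)N1CCCCC1`: > 15000 nM, a limit.
- Compound 2 `O=S(=O)(c1ccc(-c2ccc3ncnc(Nc4ccc(OCc5cccc(F)c5)c(Cl)c4)c3c2)cc1)N1CCCC1`: > 15000 nM, a limit.
- Compound 3 `CN1CCCN(S(=O)(=O)c2ccc(-c3ccc4ncnc(Nc5ccc(OCc6cccc(F)c6)c(Cl)c5)c4c3)cc2)CC1`: 1810 nM.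

Compound 3 alone gives a number; the rest is the limit of > 15000 nM in this assay, at which 2 of the 3 values shown sit. Compound 4 `O=S(=O)(c1ccc(-c2ccc3ncnc(Nc4ccc(OCc5cccc(F)c5)c(Cl)c4)c3c2)cc1)N1CCSCC1` carries thiomorpholin-4-yl in place of 4-methyl-1,4-diazepan-1-yl on a sulfonyl sulfur. The closest measured changes at this place are an at least 8.2-fold lower number from compound 1 to compound 3 (0.91 log units; beyond the scatter) and an at least 8.2-fold lower number from compound 2 to compound 3 (0.91 log units; beyond the scatter). The third, a step that the two limits leave unreadable from compound 1 to compound 2, gives no size. Among the measured compounds, only compound 3 carries 4-methyl-1,4-diazepan-1-yl, and compound 4 loses it. A return towards the limit is therefore expected in this assay. The expected change is an 8.3-fold higher number from compound 3 to compound 4 (0.92 log units; beyond the scatter), towards a higher number, similar in size to those two steps. For compound 4 the estimate is 15000 nM, with an expected range of 6000 nM to 40000 nM.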

Compound 4, half-maximal inhibitory concentration: > 15000 nM
Compound 4 ended at the assay's limit; the forecaster's own chance of this, stated with the estimate: 65%; the middle value sits exactly at the limit.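

In this assay, the change to thiomorpholin-4-yl gives an at least 8.2-fold higher number from compound 3 to compound 4 (0.91 log units; beyond the scatter) and places a sulfur-containing ring on the sulfonyl sulfur with the piperidin-1-yl and pyrrolidin-1-yl rings. Among the four sulfonyl groups, only 4-methyl-1,4-diazepan-1-yl gives a number, and the rest stay at the limit: the limit of > 15000 nM in this assay, at which 3 of the 4 values shown sit. The steps among compound 1, compound 2 and compound 4 join two limits and cannot be read.

Still open, as far as these compounds go, is whether the second ring nitrogen with its methyl or the seven-membered ring accounts for compound 3. 4-Methylpiperazin-1-yl and azepan-1-yl would separate these two features.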